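Hydroxy to acetoxy on compound 2: an expected gain

This account rests on a few compounds, and the source may have more. Where it says the series, first, only, none or still open, it means among the compounds named here.

In a functional assay on SK-MEL-28 cells (Homo sapiens) for inhibition, read by MTT assay, with a stated time of 72 h (a lower number here means a stronger inhibitor, a higher number a weaker inhibitor), compound 1 (`CCc1oc([C@H](C)/C=C(\C)[C@H](OC(C)=O)[C@H](C)[C@@H](OC(=O)CC(C)C)[C@@H](C)c2oc([C@@H](C)[C@H](CC)OC(C)=O)c(C)c(=O)c2C)c(C)c(=O)c1C`) gives 33000 nM. Compound 2 (`CCc1oc([C@H](C)/C=C(\C)[C@H](O)[C@H](C)[C@@H](OC(=O)CC(C)C)[C@@H](C)c2oc([C@@H](C)[C@@H](O)CC)c(C)c(=O)c2C)c(C)c(=O)c1C`) stands at > 100000 nM, which is a limit of the assay and not a number. Its true position is therefore open, and any step starting from compound 2 carries the same uncertainty.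

Compound 3 (`CCc1oc([C@H](C)/C=C(\C)[C@H](OC(C)=O)[C@H](C)[C@@H](OC(=O)CC(C)C)[C@@H](C)c2oc([C@@H](C)[C@@H](O)CC)c(C)c(=O)c2C)c(C)c(=O)c1C`) comes from compound 2 through a single change: acetyl in place of hydrogen on an oxygen on a saturated carbon. In words, this is acetyl in place of hydrogen on an oxygen on a saturated carbon, or hydroxy to acetoxy. Among the measured compounds shown here, no measured pair isolates this change, so its size in this assay has to be judged from two readings alone.

A modest move towards stronger inhibition is expected, because compound 1 gives 33000 nM and so shows that a measurable number is reachable in the series. A reading that stays at the limit of the assay remains quite possible. The expected change is an at least 1.6-fold lower number from compound 2 to compound 3 (0.22 log units; that floor lies within the scatter). For compound 3 the estimate is 60000 nM, with an expected range of 20000 nM to 150000 nM.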

Compound 3, half-maximal inhibitory concentration: 25000 nM
Compound 3: middle estimate off by 2.4-fold (0.38 log units), on the high side; the range from low to high includes it.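

Hydroxy to acetoxy on this oxygen on a saturated carbon gives, in this assay, an at least 4.0-fold lower number from compound 2 to compound 3 (0.60 log units; beyond the scatter), so this single acetyl is enough to bring the series from no numerical reading to a measurable one. At the second hydroxy of compound 3, the same exchange has no readable effect: a 1.3-fold lower number from compound 1 to compound 3 (0.12 log units; within the scatter), so compound 1 and compound 3 cannot be told apart in this assay, and the second acetyl is not needed for the measurable reading. Compound 2 stands at a limit of the assay and not at a number, so the first step remains a floor and its true size is unknown: the limit of > 100000 nM in this assay, at which 1 of the 3 values shown sits.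

Open, as far as these compounds go, is whether the acetyl itself matters at the first oxygen, or whether a propanoyl or benzoyl ester, or a methyl ether, would hold a reading like that of compound 3. Also open, from the compounds shown here alone, is whether an isomer of compound 3, with acetoxy only at the second oxygen and hydroxy at the first, would give a measurable number, which would show whether the gain belongs to one site or to acetylation at either.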